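Halogen swap on the sulfonyl aryl: cytotoxicity notes

This account rests on a few compounds, and the source may have more. Where it says the series, first, only, none or still open, it means among the compounds named here.

Measured compounds in an ADME assay on L02 cells (Homo sapiens) for cytotoxicity, read by MTT assay, with a stated time of 24 h; on this read-out lower numbers stand for stronger inhibition and higher numbers for weaker inhibition:
- compound 1 `O=C1/C(=C/c2cccnc2)CN(S(=O)(=O)c2ccc(Cl)cc2)C/C1=C\c1ccccc1F` gives > 20000 nM, a limit of the assay and not a number.
- compound 2 `O=C1/C(=C/c2cccnc2)CN(S(=O)(=O)c2ccc(Br)cc2)C/C1=C\c1ccccc1F` gives 14600 nM.
- compound 3 `O=C1/C(=C/c2ccncc2)CN(S(=O)(=O)c2ccc(Cl)cc2)C/C1=C\c1ccccc1C(F)(F)F` gives 14900 nM.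

Compound 2 differs from compound 1 by bromo in place of chloro on an aromatic carbon; this step reads an at least 1.3-fold lower number from compound 1 to compound 2 (0.13 log units; that floor lies within the scatter). The difference between the core of compound 1 and the core of compound 3 is not broken down here; compound 3 and compound 2 lie within the scatter of each other.

Compound 4 `O=C1/C(=C/c2ccncc2)CN(S(=O)(=O)c2ccc(Br)cc2)C/C1=C\c1ccccc1C(F)(F)F` differs from compound 3 by bromo in place of chloro on an aromatic carbon, the same change as between compound 1 and compound 2, at the same place. Since the earlier step of an at least 1.3-fold lower number from compound 1 to compound 2 (0.13 log units; that floor lies within the scatter) sits within the scatter, compound 4 is expected to stay near compound 3, with a step estimated at a 1.1-fold lower number from compound 3 to compound 4 (0.06 log units; within the scatter). The estimate for compound 4 in this assay is 13000 nM, between 6500 nM and 25000 nM.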

Compound 4, half-maximal inhibitory concentration: 12600 nM
Compound 4: the middle estimate sits 1.0-fold (0.01 log units) above what was measured; the range from low to high includes it.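

In this assay, bromo in place of chloro on the sulfonyl aryl gives a 1.2-fold lower number from compound 3 to compound 4 (0.07 log units; within the scatter). The same change on the two cores cannot be told apart: the same change on two cores in this assay, an at least 1.3-fold lower number (0.13 log units; that floor lies within the scatter) from compound 1 to compound 2 and a 1.2-fold lower number (0.07 log units; within the scatter) from compound 3 to compound 4; the limit leaves it open whether they differ

As far as these compounds go, compound 1 gives > 20000 nM, a limit of the assay and not a number, so the size of the step on its core stays unknown and carry-over between the cores is neither confirmed nor ruled out.

The compounds shown leave open how an amine, a carboxylic acid or a nitrile in place of the halogen would read in this assay. Also open, from the compounds shown here alone, is whether the bromo for chloro step stays the same on any core other than these two.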